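A few compounds are considered here, and "the series" means these few. Any claim that something is new, unique, unknown or untested is made for them only; others in the source may bear on it.

Compound 1 `COc1cc(-c2nn(-c3cccc(NC(=O)c4ccc(Cl)c(C(F)(F)F)c4)c3)cc2-c2ccncc2)ccc1Cl`: in a functional assay on SW-620 cells (Homo sapiens) for inhibition, read by sulforhodamine B assay, with a stated time of 48 h (on this read-out lower numbers stand for higher toxicity in this test and higher numbers for lower toxicity in this test), compound 1 gives > 32500 nM, which is a limit of the assay and not a number.
Compound 2 `COc1cc(-c2nn(-c3cccc(NC(=O)Nc4ccc(Cl)c(C(F)(F)F)c4)c3)cc2-c2ccncc2)ccc1Cl`: in this assay compound 2 gives > 32500 nM, again a limit.
Compound 3 `COc1cc(-c2nn(-c3cccc(NC(=O)c4ccccc4)c3)cc2-c2ccncc2)ccc1Cl`: in this assay compound 3 gives > 100000 nM, also a limit.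

Compound 2 therefore stands at a limit; it shares (the limit of > 32500 nM in this assay, at which 2 of the 3 values shown sit), while compound 3 alone sits at the limit of > 100000 nM in this assay, at which 1 of the 3 values shown sits. None of the three compounds gives a number, so the three steps among them, a step that the two limits leave unreadable from compound 1 to compound 2, a step that the two limits leave unreadable from compound 1 to compound 3 and a step that the two limits leave unreadable from compound 2 to compound 3, cannot be read in size or direction.

Compound 4 `O=C(Nc1cccc(-n2cc(-c3ccncc3)c(-c3ccc(Cl)c(O)c3)n2)c1)Nc1ccc(Cl)c(C(F)(F)F)c1` differs from compound 2 in one place: hydrogen in place of methyl on an oxygen on an aromatic ring. Within the data shown here, no measured step touches this oxygen; the three known steps all change the group on the carbonyl carbon, and every one of them is hidden by a limit. There is thus nothing in the measured data to suggest that this change would carry compound 4 out of the range where compound 2 stands, and nothing to rule it out either.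

The expectation for compound 4 is that it is estimated to give 40000 nM, within 12000 nM to 120000 nM, most probably reported again as a limit, with the step that the limit leaves unreadable from compound 2 to compound 4 expected to be no more than the scatter.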

Compound 4, concentration lethal to 50% of the cells: > 32500 nM
Compound 4: a limit, no number (the forecaster's own chance of this, stated with the estimate: 70%); the middle value does not contradict the limit.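

In this assay compound 4 gives > 32500 nM, again a limit of the assay and not a number. Compound 2 also stands at a limit, so the step from compound 2 to compound 4 cannot be read in size or direction. The compounds shown leave open what either the methoxy to hydroxy change or a change of the group on the carbonyl carbon does in this assay.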